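A few compounds are considered here, and "the series" means these few. Any claim that something is new, unique, unknown or untested is made for them only; others in the source may bear on it.

In an ADME assay on the whole organism for pharmacokinetics, with Rattus norvegicus as the target, at a dose of 2 mg/kg by the oral route (on this read-out higher numbers stand for higher oral bioavailability and lower numbers for lower oral bioavailability), compound 1 `CC1(C)CC2(CCN(C(=O)c3ccc(C[C@@H]4CC[C@H]([C@H](O)c5ccccc5)N4)cc3)CC2)C(=O)O1` gives 38%. Compound 2 `O=C(c1ccc(C[C@@H]2CC[C@H]([C@H](O)c3ccccc3)N2)cc1)N1C[C@@H]2[C@H](C1)[C@H]2c1nnco1` gives 43%, a value within the usual scatter of compound 1, so these two compounds cannot be told apart on this read-out. Compound 3 `Cn1nnc([C@H]2[C@@H]3CN(C(=O)c4ccc(C[C@@H]5CC[C@H]([C@H](O)c6ccccc6)N5)cc4)C[C@@H]32)n1` keeps the structure of compound 2 except for one group: 2-methyl-2H-tetrazol-5-yl in place of 1,3,4-oxadiazol-2-yl on a saturated ring carbon. Here, 2-methyl-2H-tetrazol-5-yl stands in place of 1,3,4-oxadiazol-2-yl on a saturated ring carbon of a three-membered non-aromatic ring of carbon only. Going by the values given here, no measured pair of compounds shows what a single swap does in this assay, so the data point in no direction, and the expectation rests on compound 2 at 43%. The expected change, a number 3 percentage points lower from compound 2 to compound 3 (within the scatter), is no step beyond the scatter. For compound 3 the estimated value is 40%, with an expected range from 22% to 58%.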

Compound 3, oral bioavailability: 56%
The estimate for compound 3 lay 16 percentage points below the measured number; the measured number falls inside the stated range.
By their numbers in this assay, from the lowest: compounds 1 and 2 (each within the scatter of the next); then compound 3.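

In this assay, putting 2-methyl-2H-tetrazol-5-yl in place of 1,3,4-oxadiazol-2-yl on a saturated ring carbon of the three-membered non-aromatic ring gives a number 13 percentage points higher from compound 2 to compound 3 (beyond the scatter), a modest step and the only single change shown here. It shows that this position is not indifferent to the group it carries: exchanging one five-membered aromatic ring for another, with the rest of the molecule unchanged, is enough to move oral bioavailability beyond the usual scatter. No measurement on hand bears on why the number rises.

The swap changes the ring and adds a methyl at once, so one pair cannot separate these two changes; 5-methyl-1,3,4-oxadiazol-2-yl on the same carbon would address that. As far as these compounds go, how an amine or a carboxylic acid would behave at this carbon also remains open.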